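Replacing the aryl sulfone with a pivaloyl group

A few compounds are considered here, and "the series" means these few. Any claim that something is new, unique, unknown or untested is made for them only; others in the source may bear on it.

Compound 2 `O=C1CC(c2ccccc2)Cc2[nH]c(=O)c(S(=O)(=O)c3ccccc3)cc21` and compound 1 `O=C1CC(c2ccccc2)Cc2[nH]c(=O)c(C(=O)c3ccccc3)cc21` share one core and differ only in the group on one aromatic carbon. In an assay for displacement of a labelled ligand from adenosine receptor A1 (Bos taurus) (a higher number here means a weaker inhibitor, a lower number a stronger inhibitor), compound 1 gives 6500 nM and compound 2 gives 5800 nM, so the two numbers sit within the scatter of each other, as the step of a 1.1-fold lower number from compound 1 to compound 2 (0.05 log units; within the scatter) shows. Compound 3 `CC(C)(C)C(=O)c1cc2c([nH]c1=O)CC(c1ccccc1)CC2=O` arises from compound 2 by (tert-butyl)carbonyl in place of phenylsulfonyl on an aromatic carbon. Within the data shown here, that single measured step is the only one bearing on this change, and it did not move the number beyond the scatter. He therefore expects at most a small shift toward a weaker value in this assay. For compound 3 his estimate is 8000 nM, between 2500 nM and 25000 nM, an expected step of a 1.4-fold higher number from compound 2 to compound 3 (0.14 log units; within the scatter).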

Compound 3, inhibition constant: 5100 nM
Compound 3: middle estimate off by 1.6-fold (0.20 log units), on the high side, and the stated range covers the measured number.
By their numbers in this assay, from the lowest: compounds 3, 2 and 1 (each within the scatter of the next).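

In this assay, this aromatic carbon now carries a group with no ring, and the number stays within the scatter (a 1.1-fold lower number from compound 2 to compound 3 (0.06 log units; within the scatter)). On the carbonyl carbon, tert-butyl in place of phenyl gives the same outcome (a 1.3-fold lower number from compound 1 to compound 3 (0.11 log units; within the scatter)), so across these three compounds an aromatic ring in this group is not required to keep the number in this range. No evidence is available to explain this result. As far as these compounds go, it remains open whether an amine or a carboxylic acid on this aromatic carbon would move the number beyond the scatter.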